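The source may hold more compounds than are shown below. What is called first, only, known or untested is meant among the compounds shown, and "the series" means these compounds.

Measured so far in a functional assay on SK-BR-3 cells (Homo sapiens) for antiproliferative activity; on this read-out higher numbers stand for weaker inhibition and lower numbers for stronger inhibition:
- compound 1 `C=CCc1cc(C(=O)Nc2cc3ccc(OC4CCN(C)CC4)c(C)c3oc2=O)ccc1OC(C)=O`: 2260 nM
- compound 2 `CC(C)=CCc1cccc(C(=O)Nc2cc3ccc(OC4CCN(C)CC4)c(C)c3oc2=O)c1`: 1680 nM
- compound 3 `Cc1c(OC2CCN(C)CC2)ccc2cc(NC(=O)c3ccccc3)c(=O)oc12`: 11500 nM

Compound 3 has the highest number of the three and is therefore the weakest inhibitor so far in this assay. Compound 4 `CC(=O)Oc1ccc(C(=O)Nc2cc3ccc(OC4CCN(C)CC4)c(C)c3oc2=O)cc1Cl` carries 4-acetoxy-3-chlorophenyl in place of phenyl on a carbonyl carbon.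

One measured single-place step bears on this change: a 6.8-fold higher number from compound 2 to compound 3 (0.84 log units; beyond the scatter), with hydrogen in place of 3-methylbut-2-en-1-yl on an aromatic carbon. Read in reverse, it links a substituent at that aromatic carbon to a lower number. Compound 1, which also carries an acetoxy group, gives 2260 nM, a lower number than compound 3 with 11500 nM. For the measured compounds named here, no measured compound here carries chlorine, so the contribution of that atom is unknown. Both comparisons point the same way, and neither compound 1 nor compound 2 goes against that direction. A modest move toward stronger inhibition is therefore expected, somewhat smaller than the measured step. The expected step is a 3.3-fold lower number from compound 3 to compound 4 (0.52 log units; beyond the scatter). For compound 4 the estimate is 3500 nM, with an expected range of 1500 nM to 8000 nM.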

Compound 4, half-maximal inhibitory concentration: 3500 nM
Estimate against measurement, compound 4: no gap at the digits printed; the range from low to high includes it.
By their numbers in this assay, from the lowest: compounds 2, 1 and 4 (each within the scatter of the next, the first and the last beyond it); then compound 3.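

In this assay the phenyl on the carbonyl carbon now has a second substituted replacement: 4-acetoxy-3-chlorophenyl gives a 3.3-fold lower number from compound 3 to compound 4 (0.52 log units; beyond the scatter) and joins the 3-(3-methylbut-2-en-1-yl)phenyl of compound 2 on the side of lower numbers. Between those two groups the exchange gives a 2.1-fold higher number from compound 2 to compound 4 (0.32 log units; beyond the scatter) and remains a small step, while chloro in place of allyl on an aromatic carbon gives a 1.5-fold higher number from compound 1 to compound 4 (0.19 log units; within the scatter) and so separates neither group from the other on this read-out. Compounds 1, 2 and 4 together show that different substituted rings at this place all keep their numbers well under that of compound 3, yet no measurement shown here accounts for any of these steps.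

Neither acetoxy nor chloro stands alone on the phenyl in the compounds shown, so the share of each in the step from the unsubstituted ring stays open. Also open, from the compounds shown here alone, is how this place responds to a hydroxy group in place of acetoxy, to an amine or a carboxylic acid on the ring, or to a longer chain in place of the ring.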